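A few compounds are considered here, and "the series" means these few. Any claim that something is new, unique, unknown or untested is made for them only; others in the source may bear on it.

Measured in a functional assay on K562 cells (Homo sapiens) for cytotoxicity, read by MTT assay, with a stated time of 5 days; on this read-out higher numbers stand for weaker inhibition and lower numbers for stronger inhibition:
- Compound 1 `COc1ccc(Cn2nncc2-c2cc(OC)c(OC)c(OC)c2)cc1N`: 730 nM
- Compound 2 `COc1ccc(-c2cnnn2Cc2cc(OC)c(OC)c(OC)c2)cc1[N+](=O)[O-]`: > 10000 nM (a limit)
- Compound 3 `COc1ccc(Cn2cc(-c3cc(OC)c(OC)c(OC)c3)nn2)cc1`: > 10000 nM (a limit)

Compound 3 gives > 10000 nM, which is a limit and not a number. It therefore stands at the limit of > 10000 nM in this assay, at which 2 of the 3 values shown sit. Compound 4 `COc1ccc(Cn2cc(-c3cc(OC)c(OC)c(OC)c3)nn2)cc1O` carries hydroxy in place of hydrogen on an aromatic carbon, ortho to a methoxy group, so 4-methoxyphenyl becomes 3-hydroxy-4-methoxyphenyl: hydroxy in place of hydrogen on an aromatic carbon. Within the data shown here, no measured pair shows this change. Compound 1, at 730 nM, shows that a related structure can give a real number in this assay. A moderate move toward stronger inhibition is therefore expected, though compound 4 may stay at the limit. The expected change is an at least 3.3-fold lower number from compound 3 to compound 4 (0.52 log units; beyond the scatter). For compound 4 the estimate is 3000 nM, within an expected range from 300 nM to 10000 nM.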

Compound 4, half-maximal inhibitory concentration: > 10000 nM
Compound 4 ended at the assay's limit; the forecaster's own chance of this, stated with the estimate: 40%; middle value at least 3.3-fold (0.52 log units) from the limit.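

Among these compounds, compound 3 and compound 4 both end at a limit rather than a number, so no step between them can be read: the limit of > 10000 nM in this assay, at which 3 of the 4 values shown sit. From the compounds shown here alone, whether hydroxy in place of hydrogen on an aromatic carbon changes inhibition at all stays open.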